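Isopropyl on the aromatic nitrogen of compound 3

A few compounds are considered here, and "the series" means these few. Any claim that something is new, unique, unknown or untested is made for them only; others in the source may bear on it.

compound 1 `CCOC(=O)c1c(C)nc(-c2ccc(OCC(C)C)c(C#N)c2)n1O`: 16800 nM
compound 2 `CCOC(=O)c1c(C)nc(-c2ccc(C#N)cc2)n1OC`: 13400 nM
compound 3 `CCOC(=O)c1[nH]c(-c2cccc(C#N)c2)nc1C`: > 30000 nM (a limit, not a number)

In a functional assay on a cell-free system (plasma, Oryctolagus cuniculus) for inhibition, with stated times of 5 min, 1 min and 6 min (a lower number here means a stronger inhibitor, a higher number a weaker inhibitor), compound 3 has no number, only a limit, > 30000 nM. It stands alone there: the limit of > 30000 nM in this assay, at which 1 of the 3 values shown sits. Going by these compounds, its true position relative to the other two compounds therefore stays open. Compound 1 and compound 2 lie within the scatter of each other, and they differ from compound 3 in more than one place.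

Compound 4 `CCOC(=O)c1c(C)nc(-c2cccc(C#N)c2)n1C(C)C` has isopropyl in place of hydrogen on an aromatic nitrogen, and otherwise keeps the structure of compound 3: isopropyl in place of hydrogen on an aromatic nitrogen.

Within the data shown here, no measured pair isolates this change, so the expectation is indirect. It rests on compound 1 at 16800 nM and compound 2 at 13400 nM, since neither has a hydrogen on that aromatic nitrogen. In this assay a small shift towards a stronger inhibitor is expected, perhaps no larger than the scatter, and a second reading at the limit would be no surprise. The expected move is an at least 1.3-fold lower number from compound 3 to compound 4 (0.13 log units; that floor lies within the scatter). For compound 4 the estimated value is 22000 nM, with an expected range of 9000 nM to 40000 nM.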

Compound 4, half-maximal inhibitory concentration: 9260 nM
Compound 4: the middle estimate sits 2.4-fold (0.38 log units) above what was measured, and the stated range covers the measured number.
By their numbers in this assay, from the lowest: compounds 4, 2 and 1 (each within the scatter of the next). At a limit, above all of these: compound 3.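

In this assay, among these compounds, replacing hydrogen with isopropyl on the aromatic nitrogen gives an at least 3.2-fold lower number from compound 3 to compound 4 (0.51 log units; beyond the scatter), the first step that can be read at a single place. The position, next to the ring atom that bears the ethoxycarbonyl group, therefore accepts a group of 3 heavy atoms, and the number falls rather than rises with that group in place. The size of the step is only a floor, since compound 3 has a limit and not a number: the limit of > 30000 nM in this assay, at which 1 of the 4 values shown sits.

The compounds shown leave open how the number responds to other groups on this aromatic nitrogen, such as a longer chain, cyclopropyl, or a chain ending in an amine or a carboxylic acid. Among the compounds shown here, compound 1 and compound 2 differ from compound 4 in more than one place, so no step to either can be read, and whether isopropyl gives a similar step with the other substitution patterns on the shared core also remains untested in this set.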